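Amino substitution on the core of compound 1

The compounds below may be only part of what the source reports. "The series", "measured", "known", "first", "only" and "open" are said of these compounds alone.

Compound 1 `ClCc1ccc(Cn2cnc3c(Cl)ncnc32)cc1` and compound 2 `ClCc1ccccc1Cn1cnc2c(Cl)nc(Cl)nc21` have both been run in a functional assay on NCI-H522 cells (Homo sapiens) for cytotoxicity, read by sulforhodamine B assay, with a stated time of 48 h; on this read-out lower numbers stand for stronger inhibition of growth and higher numbers for weaker inhibition of growth. For compound 1 the assay returns only a limit, > 100000 nM, which stands at the limit of > 100000 nM in this assay, at which 1 of the 2 values shown sits. Compound 2 gives 1990 nM in this assay. Compound 3 `Nc1nc(Cl)c2ncn(Cc3ccc(CCl)cc3)c2n1`, not yet measured, carries amino in place of hydrogen on an aromatic carbon, that is, amino in place of hydrogen on an aromatic carbon. With compound 1 at a limit, no measured step sizes this change. The expectation is a step no larger than the scatter from compound 1 to compound 3, a number no higher from compound 1 to compound 3 (the limit leaves the size open). Compound 3 is expected to give 100000 nM, within 20000 nM to 300000 nM, with another limit the likeliest outcome.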

Compound 3, concentration for total growth inhibition: 25700 nM
Beside the measured number, compound 3's estimate is 3.9-fold (0.59 log units) above it; low and high end bracket the measured number.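

In this assay, amino in place of hydrogen on an aromatic carbon, between two ring nitrogen atoms, gives an at least 3.8-fold lower number from compound 1 to compound 3 (0.59 log units; beyond the scatter), so a substituent at this position on the core of compound 1 is compatible with a measurable growth-inhibition value. This step is only a lower bound on the change, and its true size remains unknown: the limit of > 100000 nM in this assay, at which 1 of the 3 values shown sits.

As far as these compounds go, whether amino itself is required remains open, since a methylamino or hydroxyl group at this position could give a similar or a different value. From the compounds shown here alone, the effect of this change on a core carrying a different substitution pattern is also open.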